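This account rests on a few compounds, and the source may have more. Where it says the series, first, only, none or still open, it means among the compounds named here.

Values so far in a functional assay on HFF cells (Homo sapiens) for cytotoxicity (on this read-out higher numbers stand for weaker inhibition and lower numbers for stronger inhibition), each one a limit of the assay:
- compound 1 `O=S(=O)(NN1C(=S)S/C(=C\c2ccc(Cl)c(Cl)c2)C1O)c1ccc(Cl)cc1` gives > 100000 nM as a limit
- compound 2 `COc1cccc(/C=C2\SC(=S)N(NS(=O)(=O)c3ccccc3)C2=O)c1` gives > 100000 nM as a limit
- compound 3 `O=C1/C(=C/c2ccc(C(F)(F)F)cc2)SC(=S)N1NS(=O)(=O)c1ccccc1` gives > 100000 nM as a limit

Compound 2 offers no number to work from, as its > 100000 nM is a limit of the assay. The whole set sits together (the limit of > 100000 nM in this assay, at which 3 of the 3 values shown sit) and no order can be drawn among the three compounds.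

The next compound is compound 4 `O=C1/C(=C/c2ccc(Cl)c(F)c2)SC(=S)N1NS(=O)(=O)c1ccccc1`. It has 4-chloro-3-fluorophenyl in place of 3-methoxyphenyl on a double-bonded chain carbon bound to a double-bonded ring carbon. Among the compounds with values here, no measured pair isolates a single change, so the size of this step cannot be read directly. Compound 1, with chlorine on its aromatic ring, reads > 100000 nM as a limit of the assay. Compound 3, with its trifluoromethyl group, reads > 100000 nM as a limit of the assay.

On that basis no shift beyond the usual scatter is expected in this assay, and no direction is favoured. The estimated a number no higher from compound 2 to compound 4 (the limit leaves the size open) stays within that scatter. A reported limit is the more likely outcome. For compound 4 the estimate is 100000 nM with an expected range from 40000 nM to 200000 nM in this read-out.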

Compound 4, half-maximal inhibitory concentration: > 100000 nM
Compound 4: no number, only a limit; the forecaster's own chance of this, stated with the estimate: 80%; the middle value lies on the limit itself.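

In this assay compound 4 gives > 100000 nM, a limit of the assay. Compound 2 also reads as a limit, and no step can be read between compound 2 and compound 4. The compounds shown leave open at what concentration, if any, cytotoxicity would appear for any of them.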